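Demethylation of the aryl ether: a cytotoxicity estimate

This account rests on a few compounds, and the source may have more. Where it says the series, first, only, none or still open, it means among the compounds named here.

Measured so far:
compound 1 `O=C(Nc1cccc(-n2cc(-c3ccncc3)c(-c3ccc(Cl)c(O)c3)n2)c1)Nc1cccc(C(F)(F)F)c1` — > 32500 nM
compound 2 `COc1cc(-c2nn(-c3cccc(NC(=O)Nc4ccc(Cl)c(C(F)(F)F)c4)c3)cc2-c2ccncc2)ccc1Cl` — 17500 nM

In a functional assay on SF-539 cells (Homo sapiens) for inhibition, read by sulforhodamine B assay, with a stated time of 48 h (a higher number here means that more compound is tolerated, a lower number that less compound is tolerated), compound 1 reaches only a limit, > 32500 nM, as the evidence notes (the limit of > 32500 nM in this assay, at which 1 of the 2 values shown sits). For the measured compounds named here, compound 2 is the only compound with a numerical value in this assay, 17500 nM. Compound 3 `O=C(Nc1cccc(-n2cc(-c3ccncc3)c(-c3ccc(Cl)c(O)c3)n2)c1)Nc1ccc(Cl)c(C(F)(F)F)c1` differs from compound 2 by hydrogen in place of methyl on an oxygen on an aromatic ring. Going by the values given here, no step between measured compounds is available, so the size of the change is uncertain; a modest shift toward more compound being tolerated, within or slightly beyond the usual scatter, is expected, as a 1.4-fold higher number from compound 2 to compound 3 (0.15 log units; within the scatter). Compound 3 is therefore estimated at 25000 nM, between 12000 nM and 50000 nM.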

Compound 3, concentration lethal to 50% of the cells: > 32500 nM
Compound 3 gave a limit, no number; the forecaster's own chance of this, stated with the estimate: 35%; middle value at least 1.3-fold (0.11 log units) away from the limit.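

Going from methoxy to hydroxy on the 4-chloro-3-methoxyphenyl group gives the first step at this position in this assay (an at least 1.8-fold higher number from compound 2 to compound 3 (0.26 log units; that floor lies within the scatter)), and its floor does not show a change beyond the scatter. Compound 3 reaches only a limit, the same one as compound 1: the limit of > 32500 nM in this assay, at which 2 of the 3 values shown sit. The step between those two compounds, chloro in place of hydrogen on an aromatic carbon, cannot be read.

From the compounds shown here alone, the true size of the methoxy to hydroxy step stays open. So does the effect of an ethoxy group or an amine in the same place.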